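Predicting compound 4 from one repeated structural swap

The source may report more compounds than this note shows. Statements on the series, on what has been measured and on what is new or still open speak of the compounds shown alone.

All values below come from a functional assay on HT-29 cells (Homo sapiens) for cytotoxicity, read by MTT assay, with a stated time of 72 h; on this read-out higher numbers stand for weaker inhibition of growth and lower numbers for stronger inhibition of growth.
Compound 1 `CS/C(=N\C(=O)c1csc([N+](=O)[O-])c1)NC(=O)c1csc([N+](=O)[O-])c1` gives 51800 nM.
Compound 2 `CS/C(=N\C(=O)c1ccno1)NC(=O)c1ccno1` gives > 100000 nM, which is a limit of the measurement and not a number.
Compound 3 `O=C(/N=C(/NC(=O)c1ccno1)[Se]Cc1ccccc1)c1ccno1` gives 6820 nM.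

Compounds 2 and 3 share a core and differ by a group of 8 heavy atoms (7 carbon, 1 selenium; one six-membered aromatic ring of carbon only) in place of a group of 2 heavy atoms (1 carbon, 1 sulfur; no ring), on a carbon with a double bond to nitrogen. That change brought an at least 14-fold lower number from compound 2 to compound 3 (1.16 log units; beyond the scatter). The same change turns compound 1 into compound 4 `O=C(/N=C(/NC(=O)c1csc([N+](=O)[O-])c1)[Se]Cc1ccccc1)c1csc([N+](=O)[O-])c1`: a group of 8 heavy atoms (7 carbon, 1 selenium; one six-membered aromatic ring of carbon only) in place of a group of 2 heavy atoms (1 carbon, 1 sulfur; no ring), on a carbon with a double bond to nitrogen. The difference between the core of compound 1 and that of compound 2 is not broken down here. The step from compound 1 to compound 4 is expected to be a 13-fold lower number from compound 1 to compound 4 (1.11 log units; beyond the scatter), set close to the measured one but held cautiously because the value of compound 2 in this assay is known only as the limit of > 100000 nM in this assay, at which 1 of the 3 values shown sits, so the true size of that step is open. Compound 4 is therefore expected to give about 4000 nM, between 1000 nM and 15000 nM.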

Compound 4, concentration for 50% growth inhibition: 9250 nM
Compound 4: middle estimate off by 2.3-fold (0.36 log units), on the low side; low and high end bracket the measured number.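

Putting the larger selenium-containing group, with its six-membered carbon ring, in place of methylsulfanyl gave a 5.6-fold lower number from compound 1 to compound 4 (0.75 log units; beyond the scatter) in this assay, so on this second core the change again went with stronger inhibition of growth. Set side by side, the two results read: the same change on two cores in this assay, an at least 14-fold lower number (1.16 log units; beyond the scatter) from compound 2 to compound 3 and a 5.6-fold lower number (0.75 log units; beyond the scatter) from compound 1 to compound 4; the limit leaves it open whether they differ. As far as these compounds go, the direction therefore carried over in these two pairs, but whether the size carried over stays unknown, since compound 2 is known only as a limit: the limit of > 100000 nM in this assay, at which 1 of the 4 values shown sits.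

The compounds shown leave open whether a sulfur atom carrying the same ring, a longer chain or an amine on that carbon would do the same. Two cores also cannot show whether the change holds on any further core.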